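Two Quinoline Amides Measured, an Indole Analogue Awaits

The compounds below may be only part of what the source reports. "The series", "measured", "known", "first", "only" and "open" are said of these compounds alone.

Compound 1 `CCN1CCN(c2cc(C)c3cc(NC(=O)c4cccc(F)c4)ccc3n2)CC1`: 8920 nM
Compound 2 `Cc1cc(N2CCN(C(C)C)CC2)nc2ccc(NC(=O)c3ccc(Cl)c(Cl)c3)cc12`: 1710 nM

In a functional assay on MCF7 cells (Homo sapiens) for antiproliferative activity, read by MTT assay, with a stated time of 72 h (a lower number here means a stronger inhibitor, a higher number a weaker inhibitor), compound 1 gives 8920 nM, the highest of the two numbers. Its nearest neighbour is compound 2, which in this assay gives 1710 nM, a gap beyond the usual scatter; the two differ in more than one place, so the two values alone are what they show.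

Compound 3 `CCN1CCN(c2cc(C)c3cc(NC(=O)c4cc5ccccc5[nH]4)ccc3n2)CC1` has not yet been measured in this assay. It differs from compound 1 in one place: 1H-indol-2-yl in place of 3-fluorophenyl on a carbonyl carbon. Among the measured compounds shown here, no measured pair here isolates that change, so the expectation rests on the values of compound 1 and compound 2 only. Compound 3 is expected to show a moderate shift toward a lower number, the step of a 2.2-fold lower number from compound 1 to compound 3 (0.35 log units; beyond the scatter) estimated to lie beyond the scatter but well short of certainty. For compound 3 the estimate in this assay is 4000 nM, with a range from 1000 nM to 16000 nM.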

Compound 3, half-maximal inhibitory concentration: 2950 nM
Compound 3: the middle estimate sits 1.4-fold (0.13 log units) above what was measured; low and high end bracket the measured number.
By their numbers in this assay, from the lowest: compounds 2 and 3 (each within the scatter of the next); then compound 1.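

In this assay, among the compounds shown here, this is the first pair differing in one place, and it shows that the group on the carbonyl carbon can shift the number: 1H-indol-2-yl in place of 3-fluorophenyl gives a 3.0-fold lower number from compound 1 to compound 3 (0.48 log units; beyond the scatter), a modest step beyond the scatter. The exchange alters several things at once, bringing a fused five-membered aromatic ring, more heavy atoms and a hydrogen-bond donor, and this single pair cannot separate them. Nothing measured here accounts for the step.

Still open, going by these compounds, is whether a benzofuran-2-yl group, with oxygen in place of the ring nitrogen, or a smaller pyrrol-2-yl group would keep the step. Also open, on these data alone, is whether the same exchange would give a similar step in the setting of compound 2.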